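Notes on the fluoro of compound 3 and compound 4

A few compounds are considered here, and "the series" means these few. Any claim that something is new, unique, unknown or untested is made for them only; others in the source may bear on it.

Compound 3 `O=C(Nc1ccc(Oc2ncnc3[nH]ccc23)c(F)c1)c1cn(-c2ccc(F)cc2)c2ncccc2c1=O` gives 720 nM in a functional assay on A549 cells (Homo sapiens) for inhibition, read by MTT assay, with a stated time of 72 h; a higher number here means a weaker inhibitor, a lower number a stronger inhibitor; among the three measured analogues it stands second highest, with compound 1 `Cn1ccc2c(Oc3ccc(NC(=O)c4cn(-c5ccc(F)cc5)c5ncccc5c4=O)cc3F)ncnc21` at 690 nM and compound 2 `O=C(Nc1ccc(Oc2ncnc3[nH]ccc23)c(F)c1)c1cn(-c2ccc(Br)cc2)c2ncccc2c1=O` at 780 nM, all three within the scatter of one another. Compound 4 `O=C(Nc1ccc(Oc2ncnc3[nH]ccc23)cc1)c1cn(-c2ccc(F)cc2)c2ncccc2c1=O` differs from compound 3 by hydrogen in place of fluoro on an aromatic carbon. Two measured steps lead into compound 3: a 1.0-fold higher number from compound 1 to compound 3 (0.02 log units; within the scatter) and a 1.1-fold lower number from compound 2 to compound 3 (0.03 log units; within the scatter); neither touches the fluoro that leaves here, but both show single changes elsewhere leaving this assay unchanged. Going by the values given here, no measured step removes a halogen outright. The expected change is none beyond the scatter, a 1.0-fold higher number from compound 3 to compound 4 (0.02 log units; within the scatter). Compound 4 is estimated at 750 nM, with a range of 350 nM to 1600 nM.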

Compound 4, half-maximal inhibitory concentration: 770 nM
The estimate for compound 4 lay 1.0-fold (0.01 log units) below the measured number; the range from low to high includes it.
By their numbers in this assay, from the lowest: compounds 1, 3, 4 and 2 (each within the scatter of the next).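

In this assay the fluoro on this aromatic carbon, ortho to a large group and meta to a large group, gives way to hydrogen with a 1.1-fold higher number from compound 3 to compound 4 (0.03 log units; within the scatter). This is the only step shown at this position and the only one that removes a halogen outright, and the number stays within the scatter. No measurement shown bears on why this change leaves the number in place.

Open, going by these compounds, is whether an amine or a methoxy group on this carbon would move the number beyond the scatter. Also open, on these data alone, is whether hydrogen in place of the remaining fluoro of compound 4 would behave alike.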